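This account rests on a few compounds, and the source may have more. Where it says the series, first, only, none or still open, it means among the compounds named here.

Measured in a functional assay on HEL cells (Homo sapiens) for cytotoxicity; on this read-out higher numbers stand for lower toxicity in this test and lower numbers for higher toxicity in this test:
- Compound 1 `CCCCC#Cc1cc2cn(C)c(=O)nc2o1`: > 217000 nM, a limit
- Compound 2 `CCCCCCCCC#Cc1cc2cn([C@@H]3O[C@H](CO)[C@@H](O)[C@H]3O)c(=O)nc2o1`: 62000 nM

For the measured compounds named here, compound 2, at 62000 nM, holds the only actual number so far. Compound 3 `CCCCCCCCC#Cc1cc2cn(C)c(=O)nc2o1` has methyl in place of 3,4-dihydroxy-5-(hydroxymethyl)oxolan-2-yl on an aromatic nitrogen. Going by the values given here, no measured step covers this change. A small upward move in this assay is expected, since compound 1, which also bears methyl, gives the limit > 217000 nM. The estimated change is small and upward, a 1.6-fold higher number from compound 2 to compound 3 (0.21 log units; within the scatter), and may stay within the scatter. For compound 3 the expected value is 100000 nM, within an estimated range of 30000 nM to 190000 nM.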

Compound 3, half-maximal cytotoxic concentration: > 175000 nM
Compound 3 gave a limit, no number (the forecaster's own chance of this, stated with the estimate: 45%); middle value at least 1.7-fold (0.24 log units) away from the limit.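

In this assay, for the compounds shown here, methyl in place of 3,4-dihydroxy-5-(hydroxymethyl)oxolan-2-yl on the aromatic nitrogen gives an at least 2.8-fold higher number from compound 2 to compound 3 (0.45 log units; beyond the scatter), the first readable step at this position, and it points to lower toxicity in this test. On these data alone, compound 3 gives a limit, not a number, so the full size of this step stays unknown. The step between compound 1 and compound 3 cannot be read, as both values are limits. The compounds shown leave open how an aminoethyl group or a carboxylic acid on that nitrogen would read in this assay.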